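Toward a dibromohydroxyphenyl hydrazone in a triazole series

The source may hold more compounds than are shown below. What is called first, only, known or untested is meant among the compounds shown, and "the series" means these compounds.

Of the compounds shown here, three sharing one core have been measured in a functional assay on HepG2 cells (Homo sapiens) for inhibition, read by MTT assay, with a stated time of 48 h; a higher number here means a weaker inhibitor, a lower number a stronger inhibitor. Compound 1 `COc1ccc(/C=N/NC(=O)CSc2nnc(-c3ccncc3)n2-c2ccccc2)cc1` gives 27100 nM. Compound 2 `O=C(CSc1nnc(-c2ccncc2)n1-c1ccccc1)N/N=C/c1ccc(O)cc1` reaches only the limit of this assay, > 50000 nM. Compound 3 `O=C(CSc1nnc(-c2ccncc2)n1-c1ccccc1)N/N=C/c1ccc(F)cc1` gives 9330 nM, the lowest number among the three, with compound 1 as its nearest neighbour. The steps are an at least 1.8-fold higher number from compound 1 to compound 2 (0.26 log units; that floor lies within the scatter) and a 2.9-fold lower number from compound 1 to compound 3 (0.46 log units; beyond the scatter), and an at least 5.3-fold lower number from compound 2 to compound 3 (0.72 log units; beyond the scatter), where one value is a limit (the limit of > 50000 nM in this assay, at which 1 of the 3 values shown sits).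

Compound 4 `O=C(CSc1nnc(-c2ccncc2)n1-c1ccccc1)N/N=C/c1cc(Br)cc(Br)c1O` has not yet been measured. It differs from compound 3 in one place: 3,5-dibromo-2-hydroxyphenyl in place of 4-fluorophenyl on a carbon with a double bond to nitrogen. The measured steps that bear on this are the ones involving hydroxy and fluoro on the aromatic ring: an at least 5.3-fold lower number from compound 2 to compound 3 (0.72 log units; beyond the scatter) runs toward fluoro and lowers the number, while compound 4 runs back toward a hydroxy-bearing ring, so the reverse direction, a higher number, is the expected outcome. Among the measured compounds shown here, the two bromines have no measured counterpart here, so the size of their contribution is unknown. On that basis compound 4 is expected to show a 2.7-fold higher number from compound 3 to compound 4 (0.43 log units; beyond the scatter) in this assay. The estimate for compound 4 is 25000 nM, with a range from 7000 nM to 60000 nM.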

Compound 4, half-maximal inhibitory concentration: 7590 nM
The estimate for compound 4 lay 3.3-fold (0.52 log units) above the measured number; the range from low to high includes it.
By their numbers in this assay, from the lowest: compounds 4 and 3 (each within the scatter of the next); then compound 1. At a limit, above all of these: compound 2.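

In this assay, a hydroxy-bearing ring on the carbon with a double bond to nitrogen does not have to carry a high number: placing 3,5-dibromo-2-hydroxyphenyl where compound 3 has 4-fluorophenyl gives a 1.2-fold lower number from compound 3 to compound 4 (0.09 log units; within the scatter), so compound 3 and compound 4 cannot be told apart. Against the other hydroxy-bearing ring the same position shows an at least 6.5-fold lower number from compound 2 to compound 4 (0.81 log units; beyond the scatter), and against the methoxy-bearing ring it shows a 3.6-fold lower number from compound 1 to compound 4 (0.55 log units; beyond the scatter), so the outcome here depends on more than whether a hydroxy group is present. The step from compound 2 is only a floor, resting on a limit and not on a number: the limit of > 50000 nM in this assay, at which 1 of the 4 values shown sits.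

The compounds shown leave open how much of the change from compound 2 to compound 4 belongs to the two bromines and how much to the different place of the hydroxy group, as the two change together. They also leave open how this position would respond to a ring bearing a single bromine, an amine or a carboxylic acid.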